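Series notes: butynyl carbamates in a whole-animal antagonist read-out

A few compounds are considered here, and "the series" means these few. Any claim that something is new, unique, unknown or untested is made for them only; others in the source may bear on it.

Measured so far:
- compound 1, `COC(=O)N(C)CC#CCN1CCCC1`: > 10 mg/kg
- compound 2, `COC(=O)N(C)CC#CCn1cncc1C`: > 100 mg/kg
- compound 3, `COC(=O)N(C)C(C)C#CCn1cncc1C`: > 100 mg/kg

All three values come from a functional assay on the whole organism for antagonist activity, with Mus musculus as the target (on this read-out lower numbers stand for an effect already at smaller amounts and higher numbers for an effect only at larger amounts of compound), and each is a limit of the assay rather than a number. For compound 1 the value > 10 mg/kg is such a limit, as the limit of > 10 mg/kg in this assay, at which 1 of the 3 values shown sits, states. For compound 2 the value > 100 mg/kg is a limit. For compound 3 the value > 100 mg/kg is likewise a limit, and the limit of > 100 mg/kg in this assay, at which 2 of the 3 values shown sit, covers both of these. The change from compound 2 to compound 3 is methyl in place of hydrogen on a saturated chain carbon bound to an amide-type nitrogen and a triple-bonded carbon; its step that the two limits leave unreadable from compound 2 to compound 3 cannot be read, since both ends are limits. The difference between the core of compound 1 and that of compound 2 is not broken down here.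

Compound 4, `CCOC(=O)N(C)CC#CCN1CCCC1`, is not yet measured in this assay. It differs from compound 1 by methyl in place of hydrogen on a saturated chain carbon bound to an oxygen next to a carbonyl group. This is the same kind of change as from compound 2 to compound 3, not the same: there the methyl enters on a saturated chain carbon bound to an amide-type nitrogen and a triple-bonded carbon, here on a saturated chain carbon bound to an oxygen next to a carbonyl group. Since compound 1 shows only the limit > 10 mg/kg and the measured pair gives an unreadable step, the expected step from compound 1 to compound 4 is a step that the limit leaves unreadable from compound 1 to compound 4, resting on little more than the small size of the change. Compound 4 is estimated at 25 mg/kg, with a range from 6 mg/kg to 100 mg/kg, and a limit is the most likely outcome.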

Compound 4, dose for half-maximal effect: > 100 mg/kg
Compound 4: only a limit was reported; the forecaster's own chance of this, stated with the estimate: 70%; middle value at least 4.0-fold (0.60 log units) from the limit.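

In this assay, among the compounds shown here, compound 1 and compound 4 both stand only as limits of the assay, so no step between them can be read. The compounds shown leave open whether methoxycarbonyl to ethoxycarbonyl changes the read-out at all, and at what dose, if any, any of these compounds reaches a half-maximal effect.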